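The source may report more compounds than this note shows. Statements on the series, on what has been measured and on what is new or still open speak of the compounds shown alone.

Values in an assay for inhibition of Indoleamine 2,3-dioxygenase 1 (Homo sapiens), with a stated time of 1 h (a lower number here means a stronger inhibitor, a higher number a weaker inhibitor), for the three measured compounds:

compound 1 `O=C(/C(=N/O)Nc1ccc(F)c(Br)c1)C1CCN(C(=O)NCc2ccccc2)CC1`: 43 nM
compound 2 `O=C(/C(=N/O)Nc1ccc(F)c(Br)c1)C1CCCCC1`: 132 nM
compound 3 `O/N=C(/CC1CCCCC1)Nc1ccc(F)c(Br)c1`: 497 nM

Compound 1 stands at the lowest of the three numbers in this assay. Its nearest neighbour is compound 2, whose value is higher by a margin beyond the usual scatter, and compound 3 lies further off again, also beyond the scatter. No two of the measured compounds differ in a single place, so no single change carries a measured step.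

The unmeasured compound 4 `O=C(/C(=N/O)Nc1ccc(F)c(Br)c1)C1CCN(C(=O)Nc2ccccc2)CC1` is derived from compound 1 by one change: phenyl in place of benzyl on an amide-type nitrogen. Among the compounds with values here, nothing in the measured set touches this position, so no direct precedent exists for what the change does in this assay. The expectation is a step of a 1.4-fold higher number from compound 1 to compound 4 (0.14 log units; within the scatter), small and within or close to the scatter, with no strong direction. On that basis compound 4 is expected to give about 60 nM in this assay, with a range from 20 nM to 180 nM.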

Compound 4, half-maximal inhibitory concentration: 40 nM
Compound 4: middle estimate off by 1.5-fold (0.18 log units), on the high side, within the range that was stated.
By their numbers in this assay, from the lowest: compounds 4 and 1 (each within the scatter of the next); then compound 2; then compound 3.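

In this assay, within the data shown here, phenyl in place of benzyl on the amide-type nitrogen gives a 1.1-fold lower number from compound 1 to compound 4 (0.03 log units; within the scatter), the first measured step at this position. The assay therefore does not separate these two groups, and this one change leaves the inhibition of the series where it was. Nothing at hand accounts for the two groups reading alike.

From the compounds shown here alone, it remains open whether this tolerance extends beyond these two aromatic groups, for example to a longer chain such as phenethyl, a pyridyl ring, an amine or a carboxylic acid on the same nitrogen. A methyl group there would show whether an aromatic ring at this position matters to the value at all, a question that compound 1 and compound 4 cannot settle, as both carry one.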